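Swapping the Terminal Aryl Ring of a Diaryl Urea

The source may report more compounds than this note shows. Statements on the series, on what has been measured and on what is new or still open speak of the compounds shown alone.

Three compounds share one core and differ at two ends. Compound 1 `CN(C)CCn1cnnc1-c1cc(Oc2ccc(NC(=O)Nc3ccccc3C(F)(F)F)cc2F)ccn1` carries a dimethylamino chain and a 2-(trifluoromethyl)phenyl group on the urea nitrogen; in a functional assay on HT-29 cells (Homo sapiens) for antiproliferative activity, read by MTT assay, with a stated time of 72 h (a lower number here means a stronger inhibitor, a higher number a weaker inhibitor), compound 1 gives 5860 nM. Compound 3 `CCN(CC)CCn1cnnc1-c1cc(Oc2ccc(NC(=O)Nc3ccccc3C(F)(F)F)cc2F)ccn1` keeps the same aryl group but has a diethylamino chain; in this assay compound 3 gives 3410 nM, and the step of a 1.7-fold lower number from compound 1 to compound 3 (0.24 log units; within the scatter) leaves the two chains indistinguishable. Compound 2 `CCN(CC)CCn1cnnc1-c1cc(Oc2ccc(NC(=O)Nc3ccc(Cl)c(C(F)(F)F)c3)cc2F)ccn1` pairs the diethylamino chain with a 4-chloro-3-(trifluoromethyl)phenyl group, and in this assay compound 2 gives 900 nM; the step of a 3.8-fold higher number from compound 2 to compound 3 (0.58 log units; beyond the scatter) shows that the aryl group matters more than the chain. Among the three numbers, compound 3 stands second highest, close to compound 1 and clearly above compound 2.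

Compound 4 `CCN(CC)CCn1cnnc1-c1cc(Oc2ccc(NC(=O)Nc3ccc(Cl)cc3Cl)cc2F)ccn1` changes the aryl group once more: 2,4-dichlorophenyl in place of 2-(trifluoromethyl)phenyl on an amide-type nitrogen. Going by the values given here, no measured step covers this exact exchange, and the only step that touches the aryl group, a 3.8-fold higher number from compound 2 to compound 3 (0.58 log units; beyond the scatter), was modest and involved a differently substituted ring. A small change in this assay is therefore expected, if any, with its direction uncertain. Compound 4 is estimated at 2500 nM, with a range from 800 nM to 8000 nM. The expected step is a 1.4-fold lower number from compound 3 to compound 4 (0.13 log units; within the scatter).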

Compound 4, half-maximal inhibitory concentration: 3590 nM
The estimate for compound 4 lay 1.4-fold (0.16 log units) below the measured number, within the range that was stated.
By their numbers in this assay, from the lowest: compound 2; then compounds 3, 4 and 1 (each within the scatter of the next).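

In this assay, the 2,4-dichlorophenyl group on the amide-type nitrogen cannot be told apart from the 2-(trifluoromethyl)phenyl group (a 1.1-fold higher number from compound 3 to compound 4 (0.02 log units; within the scatter)), even though the exchange replaces three fluorines and an extra carbon with two chlorines. The comparison with compound 2 gives a modest step that lies beyond the scatter (a 4.0-fold higher number from compound 2 to compound 4 (0.60 log units; beyond the scatter)), so with the diethylamino chain held fixed, two differently substituted rings now give much the same result, and only the 4-chloro-3-(trifluoromethyl)phenyl group of compound 2 stands apart from them. Nothing available here explains why this one ring differs from the other two.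

The compounds shown leave open whether a simpler ring, such as 4-chlorophenyl or 3-(trifluoromethyl)phenyl, each keeping only one of the two substituents of the ring in compound 2, would match compound 2 or fall in with compound 3 and compound 4. They also leave open whether the dimethylamino chain, which made no readable difference with the 2-(trifluoromethyl)phenyl group, would behave the same way alongside the 4-chloro-3-(trifluoromethyl)phenyl group.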